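Meta-substituent changes on the alkynyl phenyl ring

The source may report more compounds than this note shows. Statements on the series, on what has been measured and on what is new or still open speak of the compounds shown alone.

Compound 2 `CC(=O)Nc1cccc(C#Cc2csc(C)n2)c1` stands at the higher of the two numbers recorded so far: in a functional assay on CHO cells for agonist activity at metabotropic glutamate receptor 5 (Homo sapiens), read by inositol phosphate accumulation (on this read-out higher numbers stand for weaker inhibition and lower numbers for stronger inhibition), compound 2 gives 2020 nM, whereas compound 1 `Cc1nc(C#Cc2cccc(OC(F)(F)F)c2)cs1` gives 266 nM. Within the data shown here, the single measured step is a 7.6-fold higher number from compound 1 to compound 2 (0.88 log units; beyond the scatter). Compound 3 `Cc1nc(C#Cc2cccc(O)c2)cs1` differs from compound 2 by hydroxy in place of acetamido on an aromatic carbon. Among the measured compounds shown here, no measured step exchanges acetamido for hydroxy, so the recorded step bears only loosely on this change. The step expected in this assay is a 1.3-fold lower number from compound 2 to compound 3 (0.13 log units; within the scatter), a small one, quite possibly within the scatter. For compound 3 the estimate in this assay is 1500 nM, with a range from 400 nM to 6000 nM.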

Compound 3, half-maximal inhibitory concentration: 654 nM
For compound 3 the middle estimate is 2.3-fold (0.36 log units) above the measured one; measured number inside the range.
By their numbers in this assay, from the lowest: compound 1; then compound 3; then compound 2.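

In this assay, the third substituent at this place separates the other two: a 3.1-fold lower number from compound 2 to compound 3 (0.49 log units; beyond the scatter), while a 2.5-fold higher number from compound 1 to compound 3 (0.39 log units; beyond the scatter), so hydroxy falls short of trifluoromethoxy but improves on acetamido. Hydroxy and acetamido have matching hydrogen-bond donor and acceptor counts, yet the step between them lies beyond the scatter, so those counts alone do not set the number here. No supporting measurement accounts for this order.

Three substituents leave open how a methoxy, an amine or a carboxylic acid at this place would compare. Whether the order holds on other aromatic positions also remains unresolved.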